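The source may report more compounds than this note shows. Statements on the series, on what has been measured and on what is new or still open speak of the compounds shown alone.

Measured compounds:
- compound 1, `CCC(=O)N1CCC(CN(C2Cc3cc(C#N)ccc3N(Cc3cncn3C)C2)S(=O)(=O)c2ccccn2)CC1`: 0.5 10^-6 cm/s
- compound 2, `Cn1cncc1CN1CC(N(CC2CCN(C(=O)CC(C)(C)C)CC2)S(=O)(=O)c2ccccn2)Cc2cc(C#N)ccc21`: 0.5 10^-6 cm/s
- compound 3, `Cn1cncc1CN1CC(N(CC2CCN(C(=O)c3ccco3)CC2)S(=O)(=O)c2ccccn2)Cc2cc(C#N)ccc21`: 0.5 10^-6 cm/s

In an ADME assay on Caco-2 cells (Homo sapiens) for permeability, in the apical to basolateral direction (a lower number here means that the compound crosses the layer more slowly, a higher number that the compound crosses the layer faster), compound 1 gives 0.5 10^-6 cm/s, and compounds 2 and 3 sit level with it. The three measured steps are all small: no change at the digits printed from compound 1 to compound 2 (within the scatter), no change at the digits printed from compound 1 to compound 3 (within the scatter) and no change at the digits printed from compound 2 to compound 3 (within the scatter). Each of them changes only the group on the carbonyl carbon at the end of the side chain, and none moves the read-out beyond the scatter.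

Compound 4, `Cn1cncc1CN1CC(N(CCn2cccc2)S(=O)(=O)c2ccccn2)Cc2cc(C#N)ccc21`, is built from compound 1 by a change of another kind: (1H-pyrrol-1-yl)methyl in place of 1-propanoylpiperidin-4-yl on a saturated chain carbon bound to a sulfonamide nitrogen. Here the whole piperidine amide side chain is exchanged for a shorter chain ending in a pyrrole ring, at the carbon bound to the sulfonamide nitrogen. Within the data shown here, no measured step touches this place, so the three steps bear on it only indirectly, by showing that compound 1 and its close relatives all stay at the same low value whatever sits on the carbonyl carbon. The expectation for compound 4 therefore rests mainly on the value of compound 1, with a wider range than usual. A modest rise is expected for compound 4, a step of a 2.0-fold higher number from compound 1 to compound 4 (0.30 log units; within the scatter), which may still fall within the scatter. Compound 4 is estimated at 1 10^-6 cm/s, with a range from 0.3 10^-6 cm/s to 4 10^-6 cm/s.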

Compound 4, apparent permeability: 12.4 10^-6 cm/s
Beside the measured number, compound 4's estimate is 12-fold (1.09 log units) below it; measured number outside the range, above it.
By their numbers in this assay, from the lowest: compounds 1, 2 and 3 (each within the scatter of the next); then compound 4.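

The earlier compounds shown here changed only the group on the carbonyl carbon and stayed level in this assay, but exchanging the whole side chain gives a 25-fold higher number from compound 1 to compound 4 (1.39 log units; beyond the scatter) and shows that the group on the saturated chain carbon bound to a sulfonamide nitrogen can move this read-out strongly. The change is not a single one: (1H-pyrrol-1-yl)methyl has fewer heavy atoms than 1-propanoylpiperidin-4-yl, has a five-membered aromatic ring instead of a six-membered non-aromatic ring, and has no double bond outside aromatic rings. No measurement available here explains the rise.

The compounds shown cannot separate these differences from one another. On these data alone, it remains open whether a phenyl ring, a plain butyl chain or a piperidine with a free amine at this place would give a value nearer compound 1 or compound 4.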